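The source may hold more compounds than are shown below. What is called first, only, known or untested is meant among the compounds shown, and "the series" means these compounds.

Within the data shown here, compound 1 `CN1CCN(c2nc(-c3ccc(Cl)cc3)nc3[nH]cnc23)CC1` stands at the low end of what is seen: in an assay on cells for displacement of a labelled ligand from adenosine receptor A2b (Homo sapiens), read by scintillation counting and radioligand binding, with a stated time of 30 min, tested at 10 uM (a lower number here means less inhibition, a higher number more inhibition at the concentration tested (going by the name of the read-out)), compound 1 gives 6.2%, the only plain number so far. Compound 2 `Oc1cccc(-c2nc(N3CCCCC3)c3nc[nH]c3n2)c1` is reported in this assay only as a limit, (the limit of > 80% in this assay, at which 1 of the 2 values shown sits), with compound 2 at > 80%. Among the measured compounds shown here, compound 3 `CN1CCN(c2nc(-c3ccc(Cl)c(C(F)(F)F)c3)nc3[nH]cnc23)CC1` differs from compound 1 by trifluoromethyl in place of hydrogen on an aromatic carbon, and no measured pair here carries such a change. For this change no shift beyond the usual scatter of this assay is expected, a number 3.8 percentage points higher from compound 1 to compound 3 (within the scatter). Compound 3 is thus expected to give about 10% in this assay, between 0% and 30%.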

Compound 3, a percentage reported as inhibition, at one concentration (the size of the read-out at that concentration, not a potency): 25.1%
Estimate against measurement, compound 3: 15.1 percentage points below; the range from low to high includes it.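

In this assay, among these compounds, trifluoromethyl in place of hydrogen on an aromatic carbon, ortho to a chloro group, gives the first readable single change: a number 18.9 percentage points higher from compound 1 to compound 3 (beyond the scatter). This place on the six-membered aromatic ring therefore takes 4 further heavy atoms with no loss of inhibition, and the read-out responds to the change. Nothing at hand accounts for this step.

As far as these compounds go, whether a nitrile or an amine at this place would shift inhibition in the same direction stays open. So does whether the step would hold without the chloro group.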